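The compounds below may be only part of what the source reports. "The series", "measured", "known", "first", "only" and "open" are said of these compounds alone.

Series notes. Compound 1 `C=CC1=C(C(=O)NCCCCC)C(c2ccc(Cl)c(Cl)c2)OC1` carries a pentyl group on the amide nitrogen; in a functional assay on SW480 cells (Homo sapiens) for cytotoxicity, read by MTT assay, with a stated time of 24 h (on this read-out higher numbers stand for weaker inhibition and lower numbers for stronger inhibition), compound 1 gives 27500 nM. Compound 2 `C=CC1=C(C(=O)Nc2ccccc2)C(c2ccc(Cl)c(Cl)c2)OC1` has a phenyl group at that nitrogen. In this assay compound 2 reaches only a limit of the assay, > 100000 nM, so its standing is known as a bound and not as a number (the limit of > 100000 nM in this assay, at which 1 of the 2 values shown sits). Among the compounds with values here, the single measured step, an at least 3.6-fold higher number from compound 1 to compound 2 (0.56 log units; beyond the scatter), therefore sets a floor on how much weaker the phenyl amide is than the pentyl amide. Compound 3 `C=CC1=C(C(=O)NC(C)(C)C)C(c2ccc(Cl)c(Cl)c2)OC1` differs from compound 2 by tert-butyl in place of phenyl on an amide-type nitrogen. This restores an alkyl substituent on the amide nitrogen, as in compound 1, though a branched one. Only an at least 3.6-fold higher number from compound 1 to compound 2 (0.56 log units; beyond the scatter) bears on the change, and it ran the opposite way; a move back toward the number of compound 1 is expected, an at least 2.2-fold lower number from compound 2 to compound 3 (0.34 log units; beyond the scatter), with real uncertainty about whether the branched group lands near the pentyl value. Compound 3 is estimated at 45000 nM in this assay, range 15000 nM to 150000 nM.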

Compound 3, half-maximal inhibitory concentration: > 100000 nM
Compound 3: only a limit was reported; the forecaster's own chance of this, stated with the estimate: 35%; middle value at least 2.2-fold (0.34 log units) from the limit.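

In this assay, the tert-butyl amide has no ring on the amide nitrogen, yet it shows an at least 3.6-fold higher number from compound 1 to compound 3 (0.56 log units; beyond the scatter). The weak reading of compound 2 therefore does not require an aromatic ring at this place, and an alkyl group on this nitrogen does not by itself keep the number of compound 1. Compound 2 and compound 3 both stand only as limits of the assay, so the step between them cannot be read and no order of the two follows: the limit of > 100000 nM in this assay, at which 2 of the 3 values shown sit.

Among the compounds shown, only the unbranched pentyl amide gives a number, which leaves open whether a shorter propyl chain or a longer octyl chain would also give one. On these data alone, it also remains open whether a cyclohexyl group, a ring without aromatic character, would read like the pentyl amide or like compound 3.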